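Shortening the Chain: From Heptyl to Isopropyl

A few compounds are considered here, and "the series" means these few. Any claim that something is new, unique, unknown or untested is made for them only; others in the source may bear on it.

Of the compounds shown here, three sharing one core have been measured in a physicochemical assay for lipophilicity, at pH 7.4; a lower number here means a more polar compound, a higher number a more lipophilic compound. Compound 1 `CCc1c(C)[nH]c2cc(OC)c(Cl)cc2c1=O` gives 2.43. Compound 3 `CCCCCCCCCc1c(C)[nH]c2cc(OC)c(Cl)cc2c1=O` gives 4.74. For compound 2 `CCCCCCCc1c(C)[nH]c2cc(OC)c(Cl)cc2c1=O` only a limit of the assay is known, < 3.83. Compound 2 thus stands at the limit of < 3.83 in this assay, at which 1 of the 3 values shown sits, with no number of its own. The measured steps rise with chain length: a number 2.31 log units higher from compound 1 to compound 3 (beyond the scatter) and a number at least 0.91 log units higher from compound 2 to compound 3 (beyond the scatter), while a step that the limit leaves unreadable from compound 1 to compound 2. Compound 4 `COc1cc2[nH]c(C)c(C(C)C)c(=O)c2cc1Cl` differs from compound 2 in that (isopropyl in place of heptyl on an aromatic carbon). Isopropyl is far shorter than heptyl and nearer in size to ethyl, so a downward step is expected, estimated as a step that the limit leaves unreadable from compound 2 to compound 4. Compound 4 is expected at 2.75, within a range from 2.4 to 3.1.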

Compound 4, distribution coefficient: 2.84
Estimate against measurement, compound 4: 0.09 log units below; low and high end bracket the measured number.
By their numbers in this assay, from the lowest: compound 1; then compound 4; then compound 3.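

In this assay, methyl in place of hydrogen on the saturated chain carbon bound to an aromatic carbon gives a number 0.41 log units higher from compound 1 to compound 4 (beyond the scatter), so a single added carbon at this position already moves the number beyond the scatter. The step from heptyl to isopropyl cannot be read, since compound 2 carries only a limit: the limit of < 3.83 in this assay, at which 1 of the 4 values shown sits.

The compounds shown leave open whether an unbranched propyl chain at this position would read like isopropyl. As far as these compounds go, how a cyclopropyl group or a chain ending in an amine would read also stays open.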